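Methoxy on the chloropyridine core: what one earlier step suggests

The source may hold more compounds than are shown below. What is called first, only, known or untested is meant among the compounds shown, and "the series" means these compounds.

The study compares three measured compounds and one not yet measured, all built on a bicyclic amine scaffold. Compound 1 `Clc1ccc(C2=CC3CNCC(C2)C3)cn1` gives 6.2 nM in an in vitro assay on SH-SY5Y cells for displacement of a labelled ligand from Neuronal acetylcholine receptor; alpha3/beta4 (Homo sapiens); on this read-out lower numbers stand for stronger inhibition and higher numbers for weaker inhibition. Compound 3 `C1=C(c2cncc(Oc3ccccc3)c2)CC2CNCC1C2` gives 1.9 nM in this assay, and compound 2 `COc1ccccc1Oc1cncc(C2=CC3CNCC(C2)C3)c1` gives 56 nM. The difference between the cores of compound 1 and compound 3 is not broken down here.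

Compound 2 differs from compound 3 by methoxy in place of hydrogen on an aromatic carbon. This change produced a 29-fold higher number from compound 3 to compound 2 (1.47 log units; beyond the scatter).

Compound 4 `COc1cc(C2=CC3CNCC(C2)C3)cnc1Cl` has not been measured. It differs from compound 1 by methoxy in place of hydrogen on an aromatic carbon. Among the measured compounds shown here, the change is the same kind of change as the one from compound 3 to compound 2, but the surroundings differ: in compound 2 the methoxy sits on a six-membered aromatic ring of carbon only, ortho to a large group, whereas in compound 4 it sits on a six-membered aromatic ring with 1 nitrogen, ortho to a chloro group, two atoms from the ring nitrogen and meta to a group of 9 heavy atoms.

For the measured compounds named here, because the one measured example of this kind of change gave a 29-fold higher number from compound 3 to compound 2 (1.47 log units; beyond the scatter), a weakening is expected for compound 4 as well, though a smaller one, since the methoxy enters a different environment. The expected step from compound 1 to compound 4 in this assay is a 3.2-fold higher number from compound 1 to compound 4 (0.51 log units; beyond the scatter). Compound 4 is therefore estimated at 20 nM in this assay, with a range from 6 nM to 65 nM.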

Compound 4, inhibition constant: 7 nM
Estimate against measurement, compound 4: 2.9-fold (0.46 log units) above, and the stated range covers the measured number.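

Placing methoxy in place of hydrogen on an aromatic carbon of the core of compound 1 gives a 1.1-fold higher number from compound 1 to compound 4 (0.05 log units; within the scatter) in this assay, so on this core the change has no effect that can be read. Set beside the earlier step, the same kind of change does not carry its size from one core to the other: the same change on two cores in this assay, a 29-fold higher number (1.47 log units; beyond the scatter) from compound 3 to compound 2 and a 1.1-fold higher number (0.05 log units; within the scatter) from compound 1 to compound 4, 26-fold (1.42 log units) apart, beyond the scatter of two such steps. Among the compounds shown here, this shows that, within these two pairs, the step seen on one core is no guide to the step on the other, but it does not show what sets them apart: the methoxy sits on a six-membered aromatic ring of carbon only in compound 2 and on a six-membered aromatic ring with 1 nitrogen in compound 4, and one pair for each core gives no rule for the series.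

The compounds shown leave open whether an ethoxy group, an amine or a carboxylic acid at the methoxy position of compound 4 would also stay within the scatter of compound 1. They also leave open whether methoxy would behave the same way at other positions on either core, or on the core of compound 1 with the chloro group replaced by hydrogen.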